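Adding a Hydroxymethyl Group to a Lactone Inhibitor

A few compounds are considered here, and "the series" means these few. Any claim that something is new, unique, unknown or untested is made for them only; others in the source may bear on it.

Compound 2 `Cc1cc(C)c(/C=C/[C@@H]2C[C@@H](O)CC(=O)O2)c(-c2ccc(F)cc2)c1` was tested in an assay for inhibition of 3-hydroxy-3-methylglutaryl-coenzyme A reductase (Rattus norvegicus) (a lower number here means a stronger inhibitor, a higher number a weaker inhibitor), where compound 2 gives 13 nM. Compound 1 `Cc1cc(C)cc(-c2cc(Cl)cc(Cl)c2/C=C/[C@@H]2C[C@@H](O)CC(=O)O2)c1` gives 13 nM, the same number at the digits shown, so the two stand together at the lowest level of the three. Within the data shown here, compound 3 `O=C1C[C@H](O)C[C@@H](/C=C/c2c(Cl)cc(Cl)cc2-c2cccc(F)c2)O1` gives 70 nM; the only single-point step known, a 5.4-fold higher number from compound 1 to compound 3 (0.73 log units; beyond the scatter), swaps the whole aromatic substituent on the shared core. Compound 4 `Cc1cc(C)c(/C=C/[C@@H]2C[C@@H](O)CC(=O)O2)c(-c2ccc(F)c(CO)c2)c1` differs from compound 2 by hydroxymethyl in place of hydrogen on an aromatic carbon. Among the measured compounds shown here, no measured step touches this part of the molecule, so the one step known does not bear on it directly. Compound 4 is therefore expected to show a 1.2-fold higher number from compound 2 to compound 4 (0.06 log units; within the scatter), little or nothing beyond the scatter. For compound 4 the estimate is 15 nM, with a range from 5 nM to 45 nM.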

Compound 4, half-maximal inhibitory concentration: 49 nM
The estimate for compound 4 lay 3.3-fold (0.51 log units) below the measured number; measured number outside the range, above it.
By their numbers in this assay, from the lowest: compounds 1 and 2 (each within the scatter of the next); then compounds 4 and 3 (each within the scatter of the next).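

In this assay, the position ortho to the fluoro group proves sensitive to substitution: hydroxymethyl in place of hydrogen gives a 3.8-fold higher number from compound 2 to compound 4 (0.58 log units; beyond the scatter), a modest step beyond the scatter. Compound 4 remains an inhibitor in the nanomolar range, so this added group weakens inhibition without abolishing it. Nothing available explains this loss.

From the compounds shown here alone, what a methyl group, an amine or a carboxylic acid would do at this position remains open. Also open, going by these compounds, is whether the hydroxyl or the added carbon accounts for the change.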